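Aryl swap on the piperazine nitrogen: fluoro to chloro

This account rests on a few compounds, and the source may have more. Where it says the series, first, only, none or still open, it means among the compounds named here.

Compound 1, `Nc1scc(CN2CCN(c3cccc(Cl)c3Cl)CC2)c1C(=O)c1ccc(Cl)cc1`: in a functional assay on CHO cells with adenosine receptor A1 (Homo sapiens) as the target, read by cAMP accumulation and immunoassay, with a stated time of 6 min, tested at 10 uM (on this read-out higher numbers stand for a weaker effect at the one concentration tested and lower numbers for a stronger effect), compound 1 gives -77%.
Compound 2, `Nc1scc(CN2CCN(c3cccc(C(F)(F)F)c3)CC2)c1C(=O)c1ccc(Cl)cc1`: in this assay compound 2 gives -80%.
Compound 3, `Nc1scc(CN2CCN(c3ccc(F)c(Cl)c3)CC2)c1C(=O)c1ccc(Cl)cc1`: in this assay compound 3 gives -78%.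

Compound 3 sits second highest of the three numbers, but its neighbours are close: the step of a number 1 percentage points lower from compound 1 to compound 3 (within the scatter) and the step of a number 2 percentage points higher from compound 2 to compound 3 (within the scatter) are both within the scatter, so the three compounds cannot be told apart on this read-out. The same holds for a number 3 percentage points lower from compound 1 to compound 2 (within the scatter).

Compound 4, `Nc1scc(CN2CCN(c3ccc(Cl)c(Cl)c3)CC2)c1C(=O)c1ccc(Cl)cc1`, has not been measured. It differs from compound 3 by chloro in place of fluoro on an aromatic carbon. All three measured steps alter the aryl group on the same amine nitrogen in a ring, and none of them moved the read-out beyond the scatter. The change to compound 4 is the smallest of these, so no step beyond the scatter is expected, and no change at the digits printed from compound 3 to compound 4 (within the scatter) is the estimated step.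

Compound 4 is therefore expected to give about -78% in this assay, within a range of -87% to -69%.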

Compound 4, a percentage reported as activity, at one concentration (the size of the read-out at that concentration, not a potency): -62%
Estimate against measurement, compound 4: 16 percentage points below, and the stated range ends below it.
By their numbers in this assay, from the lowest: compounds 2, 3 and 1 (each within the scatter of the next); then compound 4.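

Among these compounds, the exchange of fluoro for chloro, on an aromatic carbon ortho to a chloro group and para to a large group, is the first change to this aryl group that passes the scatter in this assay, with a number 16 percentage points higher from compound 3 to compound 4 (beyond the scatter) as its result. The 3,4-dichlorophenyl group also separates compound 4 from the other two aryl groups, with a number 18 percentage points higher from compound 2 to compound 4 (beyond the scatter) and a number 15 percentage points higher from compound 1 to compound 4 (beyond the scatter) as the steps, so that even 2,3-dichlorophenyl does not match it and compound 4 has the weakest effect of the four at the one concentration tested. No measurement given here accounts for this shift.

The compounds shown leave open whether a bromo, methyl or nitrile group on the same carbon would stay with compound 3 or move with compound 4. They also leave open how these four compare across a range of concentrations.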